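A few compounds are considered here, and "the series" means these few. Any claim that something is new, unique, unknown or untested is made for them only; others in the source may bear on it.

Of the compounds shown here, three have so far been measured in a functional assay on NCI-H520 cells (Homo sapiens); a higher number here means a weaker inhibitor of growth, a lower number a stronger inhibitor of growth. Compound 1 `O=S(=O)(/C=C/c1ccc(F)cc1)Cc1ccc(Nc2ncnc3ccccc23)cc1` gives 13000 nM, and compound 2 `O=S(=O)(/C=C/c1ccc(Cl)cc1Cl)Cc1ccc(Nc2ncnc3ccccc23)cc1` gives 12000 nM. The step of a 1.1-fold higher number from compound 2 to compound 1 (0.03 log units; within the scatter) rests on (4-fluorophenyl in place of 2,4-dichlorophenyl on a double-bonded chain carbon bound to a double-bonded chain carbon). Compound 3 `COc1cc2ncnc(Nc3ccc(CS(=O)(=O)/C=C/c4ccc(Cl)cc4Cl)cc3)c2cc1OC` carries another core; in this assay compound 3 gives 6000 nM. The difference between the core of compound 3 and the core of compound 2 is not broken down here. Compound 4 `COc1cc2ncnc(Nc3ccc(CS(=O)(=O)/C=C/c4ccc(F)cc4)cc3)c2cc1OC` has not yet been measured; it differs from compound 3 by 4-fluorophenyl in place of 2,4-dichlorophenyl on a double-bonded chain carbon bound to a double-bonded chain carbon, the same change at the same place as between compound 2 and compound 1. Because the earlier step of a 1.1-fold higher number from compound 2 to compound 1 (0.03 log units; within the scatter) stayed within the scatter, a similarly small step is expected here, a 1.1-fold higher number from compound 3 to compound 4 (0.03 log units; within the scatter). In this assay compound 4 is therefore estimated at 6500 nM, between 3000 nM and 14000 nM.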

Compound 4, concentration for 50% growth inhibition: > 100000 nM
Compound 4 was reported as a limit; the forecaster's own chance of this, stated with the estimate: 5%; at least 15-fold (1.18 log units) between middle value and limit.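

In this assay the change from 2,4-dichlorophenyl to 4-fluorophenyl brings an at least 16-fold higher number from compound 3 to compound 4 (1.22 log units; beyond the scatter) and so does not carry over unchanged from one core to the other: the same change on two cores in this assay, a 1.1-fold higher number (0.03 log units; within the scatter) from compound 2 to compound 1 and an at least 16-fold higher number (1.22 log units; beyond the scatter) from compound 3 to compound 4, at least 15-fold (1.18 log units) apart, beyond the scatter of two such steps. Compound 4 gives > 100000 nM and this is a limit of the assay, not a number: the limit of > 100000 nM in this assay, at which 1 of the 4 values shown sits. These two pairs show that the outcome of this change depends on the core it sits on, but they do not show which part of the core matters or why, and they set no rule for other cores.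

Open, from the compounds shown here alone, is how a plain phenyl or a 4-chlorophenyl in the same place would behave on each of the two cores. Such compounds could show whether the large step follows the chlorine atoms or the fluorine.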